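Chlorophenyl substitution pattern on the shared core

The source may hold more compounds than are shown below. What is called first, only, known or untested is meant among the compounds shown, and "the series" means these compounds.

Measured compounds:
Compound 1 `Oc1cccc(-c2cc(-c3ccc(Cl)cc3)nc(-c3ccsc3)c2)c1` gives 8850 nM in a functional assay on HCT-15 cells (Homo sapiens) for cytotoxicity, read by CCK-8 assay and cell counting, with a stated time of 2 days; a lower number here means a stronger inhibitor, a higher number a weaker inhibitor.
Compound 2 `Oc1cccc(-c2cc(-c3ccc(Cl)cc3)nc(-c3cccnc3)c2)c1` gives 16800 nM in this assay.
Compound 3 `Oc1cccc(-c2cc(-c3ccncc3)nc(-c3cccc(Cl)c3)c2)c1` gives "not determined" (no result reported) in this assay, so it has no reported number there.

Among the measured compounds shown here, compound 3 therefore stands nowhere on the numbers: no result was obtained for it, so there is no starting value to step from. The change to compound 4 `Oc1cccc(-c2cc(-c3ccncc3)nc(-c3ccc(Cl)cc3)c2)c1` is 4-chlorophenyl in place of 3-chlorophenyl on an aromatic carbon.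

For the measured compounds named here, the one measured step, a 1.9-fold higher number from compound 1 to compound 2 (0.28 log units; within the scatter), concerns a different position on the core and does not bear on this change; no step among the measured compounds moves a chlorine around the chlorophenyl ring. Compound 4 shares its 4-chlorophenyl group with compound 1 and compound 2, whose values in this assay lie within the scatter of each other, and this is the only anchor available. Going by the values given here, with no measured step to guide direction, no shift beyond the scatter can be predicted, and the expectation rests on the range spanned by compound 1 and compound 2 alone. Compound 4 is thus expected to give about 14000 nM in this assay, with a range from 5000 nM to 45000 nM.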

Compound 4, half-maximal inhibitory concentration: 2630 nM
Beside the measured number, compound 4's estimate is 5.3-fold (0.73 log units) above it, and the stated range ends above it.
By their numbers in this assay, from the lowest: compound 4; then compounds 1 and 2 (each within the scatter of the next).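

From the compounds shown here alone, compound 3 has no number in this assay, so the step from 3-chlorophenyl to 4-chlorophenyl cannot be read and the chlorine position remains untested. With 4-chlorophenyl held constant, the other aryl position now separates the compounds: pyridin-4-yl gives a 6.4-fold lower number from compound 2 to compound 4 (0.81 log units; beyond the scatter) and a 3.4-fold lower number from compound 1 to compound 4 (0.53 log units; beyond the scatter) as changes beyond the scatter, while the earlier 1.9-fold higher number from compound 1 to compound 2 (0.28 log units; within the scatter) did not separate pyridin-3-yl from thiophen-3-yl. No supporting measurement is available to explain why pyridin-4-yl gives the lowest number of the three compounds.

Open, going by these compounds, is whether the 3-chlorophenyl and 4-chlorophenyl groups differ at all when pyridin-4-yl is present. Also open, on these data alone, is how an amine or a carboxylic acid in place of pyridin-4-yl, or a methoxy group in place of the chlorine, would read in this assay on the shared core.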